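The source may hold more compounds than are shown below. What is called first, only, known or untested is meant among the compounds shown, and "the series" means these compounds.

Working notes on the series, read in a functional assay on DU-145 cells (Homo sapiens) for inhibition, read by trypan blue exclusion, with a stated time of 96 h; on this read-out lower numbers stand for stronger inhibition of growth and higher numbers for weaker inhibition of growth. Within the data shown here, compound 2 `COc1cc(OC)c(/C=C(/SCc2ccc(Cl)cc2)C(=O)c2ccc(Br)cc2)c(OC)c1` gives 1000 nM, the lower of the two true numbers so far. Compound 3 `COc1cc(OC)c(/C=C(\C(=O)c2ccc(Br)cc2)S(=O)(=O)Cc2ccc(Cl)cc2)c(OC)c1` gives 25000 nM. It is the sulfonyl counterpart of compound 2. Compound 1 `COc1cc(OC)c(/C=C(\C(=O)c2ccc(Br)cc2)S(=O)(=O)c2ccc(Br)cc2)c(OC)c1` reads > 100000 nM, which is a limit and not a number (the limit of > 100000 nM in this assay, at which 1 of the 3 values shown sits).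

Compound 4 `COc1cc(OC)c(/C=C(/SCc2ccc(Cl)cc2)C(=O)c2ccc([N+](=O)[O-])cc2)c(OC)c1` keeps the (4-chlorobenzyl)sulfanyl of compound 2 and departs from it at one place: nitro in place of bromo on an aromatic carbon.

The measured steps all lie on the sulfur side: a 25-fold higher number from compound 2 to compound 3 (1.40 log units; beyond the scatter), an at least 100-fold lower number from compound 1 to compound 2 (2.00 log units; beyond the scatter) and an at least 4.0-fold lower number from compound 1 to compound 3 (0.60 log units; beyond the scatter). All three measured compounds carry the same 4-bromophenyl, so none of these steps tests the change from 4-bromophenyl to 4-nitrophenyl. They show only that this assay can move widely within this series, which argues for a broad range but gives no direction. With no direct evidence at this site, no step beyond the scatter is the default expectation, held loosely. The expected change is no change at the digits printed from compound 2 to compound 4 (within the scatter). For compound 4 the estimated value is 1000 nM, with an expected range of 200 nM to 5000 nM.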

Compound 4, concentration for 50% growth inhibition: > 100000 nM
Compound 4: only a limit was reported; the forecaster's own chance of this, stated with the estimate: 5%; middle value at least 100-fold (2.00 log units) from the limit.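

In this assay, the replacement of 4-bromophenyl by 4-nitrophenyl gives an at least 100-fold higher number from compound 2 to compound 4 (2.00 log units; beyond the scatter), the only reading among the compounds shown at this site, which compound 1, compound 2 and compound 3 all hold constant. Compound 4 reads > 100000 nM, which is a limit and not a number, and compound 1 sits at the same limit: the limit of > 100000 nM in this assay, at which 2 of the 4 values shown sit. The site on the far side of the carbonyl is therefore not a silent one: with nitro in place of bromo on that aromatic carbon, the (4-chlorobenzyl)sulfanyl shared by compound 2 and compound 4 does not by itself retain growth inhibition in this assay.

With a single replacement at this site, the compounds shown cannot separate an effect of nitro in particular from one of any departure from bromo, and a chloro, a methoxy or an amino group on the same aromatic carbon would bear on that question. Also open, going by these compounds, is whether nitro in place of bromo would move the sulfonyl counterpart, compound 3, in the same direction as it moves the sulfanyl compound 2.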